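The compounds below may be only part of what the source reports. "The series", "measured", "known", "first", "only" and "open" are said of these compounds alone.

Measured so far, in a functional assay on MDA-MB-231 cells (Homo sapiens) for inhibition, read by sulforhodamine B assay, with a stated time of 72 h; on this read-out lower numbers stand for stronger inhibition of growth and higher numbers for weaker inhibition of growth:

Compound 1 `CNC(=O)/C=C/c1ccncc1-c1ccc2ccccc2c1` gives 8680 nM.
Compound 2 `O=C(O)/C=C/c1ccncc1-c1ccc2ccccc2c1` reaches only a limit of the assay, > 10000 nM.
Compound 3 `Cn1ccc2cc(-c3cnccc3/C=C/C(=O)O)ccc21` likewise reaches only a limit of the assay, > 10000 nM.

Compound 1 and compound 2 share one core and differ in one place: methylamino in place of hydroxy on a carbonyl carbon. In this assay this change gives an at least 1.1-fold lower number from compound 2 to compound 1 (0.06 log units; that floor lies within the scatter), a step that rests on a limit at one end, since compound 2 sits at the limit of > 10000 nM in this assay, at which 2 of the 3 values shown sit, together with compound 3.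

Compound 4 `CNC(=O)/C=C/c1ccncc1-c1ccc2c(ccn2C)c1` has not yet been measured. It stands to compound 3 as compound 1 stands to compound 2: methylamino in place of hydroxy on a carbonyl carbon. The place of the change is described in the same words for both pairs, so it is the same change, set on a different core. How the core of compound 3 differs from the core of compound 2 is not broken down here.

Because compound 3 only reached a limit, > 10000 nM, and because the measured step from compound 2 to compound 1 was an at least 1.1-fold lower number from compound 2 to compound 1 (0.06 log units; that floor lies within the scatter), the step from compound 3 to compound 4 in this assay is expected to be small as well, about a step that the limit leaves unreadable from compound 3 to compound 4. On that basis compound 4 is estimated at 12000 nM in this assay, with a likely range from 5000 nM to 40000 nM, and a fair chance that the assay again reports only a limit rather than a number.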

Compound 4, concentration for 50% growth inhibition: 8550 nM
Beside the measured number, compound 4's estimate is 1.4-fold (0.15 log units) above it; the range from low to high includes it.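

In this assay, putting methylamino in place of hydroxy on the carbonyl carbon, which turns carboxy into methylcarbamoyl, gives an at least 1.1-fold lower number from compound 3 to compound 4 (0.06 log units; that floor lies within the scatter). On both cores the methylcarbamoyl compound returns a number where the carboxy compound returns only a limit, but the sizes of the two steps cannot be set against each other: the same change on two cores in this assay, an at least 1.1-fold lower number (0.06 log units; that floor lies within the scatter) from compound 2 to compound 1 and an at least 1.1-fold lower number (0.06 log units; that floor lies within the scatter) from compound 3 to compound 4; the limit leaves it open whether they differ This shows that the same kind of result appears on two cores, but it does not show that the change carries over with the same size, or that it strengthens growth inhibition by more than the usual scatter, since the starting point of each step is not a true number: the limit of > 10000 nM in this assay, at which 2 of the 4 values shown sit.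

Going by these compounds, what stays open first is where the two carboxy compounds would fall if the assay gave numbers for them, and so how large each step really is. Also open, on these data alone, is whether other groups on the carbonyl carbon, such as dimethylamino, ethylamino or a methyl ester, would behave like methylamino on either core, and what a longer chain in place of the 2-(methylcarbamoyl)ethenyl group would do.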